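This account rests on a few compounds, and the source may have more. Where it says the series, first, only, none or still open, it means among the compounds named here.

Compound 1 `CNc1cc(Oc2ccc(NC(=O)Nc3cccc(C(F)F)c3)cc2)ncn1` gives 100 nM in an assay on isolated protein for inhibition of serine/threonine-protein kinase TNNI3K (Homo sapiens); on this read-out higher numbers stand for weaker inhibition and lower numbers for stronger inhibition.
Compound 2 `CNc1cc(Oc2ccc(NC(=O)Nc3cccc(C(F)(F)F)c3)cc2Cl)ncn1` gives 50 nM in this assay.
Compound 3 `CNc1cc(Oc2ccc(NC(=O)Nc3cccc(C(F)(F)F)c3)cc2)ncn1` gives 40 nM in this assay.

Compound 3 has the lowest number of the three. Its gap to compound 2 lies within the scatter, so the two cannot be told apart, while the step from compound 1 is larger: a 2.5-fold lower number from compound 1 to compound 3 (0.40 log units; beyond the scatter), a modest but real difference.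

Compound 4 `C[C@H](O)CNc1cc(Oc2ccc(NC(=O)Nc3cccc(C(F)(F)F)c3)cc2)ncn1` is compound 3 with one alteration: 1-hydroxyethyl in place of hydrogen on a saturated chain carbon bound to a nitrogen on an aromatic ring. Neither measured step touches this part of the shared core. The step of a 2.5-fold lower number from compound 1 to compound 3 (0.40 log units; beyond the scatter) concerns the fluorine count on the saturated chain carbon, and the step of a 1.3-fold lower number from compound 2 to compound 3 (0.10 log units; within the scatter) concerns the chloro on the aromatic ring. Among the measured compounds shown here, there is thus no measured precedent for enlarging the methylamino to a (2-hydroxypropyl)amino, and the expectation rests only on the fact that the rest of the structure is unchanged.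

Compound 4 is therefore expected to stay close to compound 3, with no step beyond the scatter: no change at the digits printed from compound 3 to compound 4 (within the scatter). The estimate for compound 4 in this assay is 40 nM, with a range from 13 nM to 120 nM.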

Compound 4, half-maximal inhibitory concentration: 32 nM
Compound 4: middle estimate off by 1.3-fold (0.10 log units), on the high side; measured number inside the range.
By their numbers in this assay, from the lowest: compounds 4, 3, 2 and 1 (each within the scatter of the next, the first and the last beyond it).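

Changing methylamino to (2-hydroxypropyl)amino brings a 1.3-fold lower number from compound 3 to compound 4 (0.10 log units; within the scatter) in this assay, so the two compounds cannot be told apart on this read-out. Compounds 1, 2 and 3 all carry methylamino, which makes this the only change at this position among the compounds shown, and it shows that a 2-hydroxypropyl group with a defined stereocentre can stand here with no step beyond the scatter. No measurement at hand gives a reason for this result.

The compounds shown leave open whether the mirror-image form of the 2-hydroxypropyl group, or a longer chain ending in an amine, would give a similar number. They also leave open what the hydroxyl contributes, a question that a plain propyl group at this position could address.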